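This account rests on a few compounds, and the source may have more. Where it says the series, first, only, none or still open, it means among the compounds named here.

Measured compounds:
- compound 1, `CC1(C)CCC(C)(C)c2c1cc(O)c(C(=O)c1ccc3cc(C(=O)O)ccc3c1)c2F`, gives 87% in an assay on isolated protein with retinoic acid receptor beta (Homo sapiens) as the target; on this read-out lower numbers stand for smaller maximal responses and higher numbers for larger maximal responses
- compound 2, `COc1c(C(=O)c2ccc3c(c2)C(C)(C)CCC3(C)C)ccc2cc(C(=O)O)ccc12`, gives 0% in this assay

Compound 2 stands at the bottom of these two numbers: its value lies far beneath that of compound 1, a gap well beyond the usual scatter. Within the data shown here, the two compounds differ in more than one place, so no single step between them is recorded; the values only show that one of the pair reaches a large response and the other none.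

Compound 3, `CC1(C)CCC(C)(C)c2cc(C(=O)c3ccc4cc(C(=O)O)ccc4c3O)ccc21`, has not yet been measured. It differs from compound 2 in one place only: hydrogen in place of methyl on an oxygen on an aromatic ring. Cut one bond further out, the change reads methoxy to hydroxy, and a hydroxy group is also carried by compound 1, whereas compound 2 carries a methoxy group.

Among the measured compounds shown here, no measured pair isolates this change, so the size of the step is uncertain. An upward step in this assay is expected, of the order of a number 50 percentage points higher from compound 2 to compound 3 (beyond the scatter), beyond the scatter. For compound 3 the expected value is 50%, with a range from 10% to 90%.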

Compound 3, largest response reached (reported as maximum), in percent of the reference or control that the assay uses: 0%
Estimate against measurement, compound 3: 50 percentage points above; the whole stated range lies above it.
By their numbers in this assay, from the lowest: compounds 2 and 3 (each within the scatter of the next); then compound 1.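

In this assay, replacing methoxy with hydroxy on the oxygen on the aromatic ring gives no change at the digits printed from compound 2 to compound 3 (within the scatter). Hydrogen and methyl on this oxygen therefore cannot be told apart by this read-out on this core, and freeing the hydroxy group does not by itself bring a response. Nothing available explains why the response stays absent in both compounds.

As far as these compounds go, since compound 2 and compound 3 both sit at the bottom of the read-out, this pair cannot show whether any group on this oxygen could push the response lower, and it remains open whether something other than hydrogen or methyl, such as an ethyl group, a longer chain or a chain ending in an amine, would produce a response at this place. Also open is what accounts for the large response of compound 1, which gives 87% in this assay but differs from compound 3 in more than one place, so no single change can be read from that pair.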